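The source may hold more compounds than are shown below. What is called first, only, known or untested is meant among the compounds shown, and "the series" means these compounds.

For the measured compounds named here, in a physicochemical assay for lipophilicity, at pH 7.4 (on this read-out higher numbers stand for higher lipophilicity and lower numbers for lower lipophilicity), three compounds built on one shared core have numbers so far. Compound 1 `CCOc1ccc2c(c1)C=CN(C)C(=O)C2C` gives 5, compound 2 `CC1C(=O)N(C)C=Cc2cc(OCC(C)(C)O)ccc21` gives 3.6, and compound 3 `C[C@H]1C(=O)N(C)C=Cc2cc(OC(CO)CO)ccc21` gives 1.3. Compound 3 is the lowest of the three, and its distance from each of the other two lies beyond the scatter.

The unmeasured compound 4 `C[C@H]1C(=O)N(C)C=Cc2cc(CCO)ccc21` differs from compound 3 on an aromatic carbon: 2-hydroxyethyl in place of 2-hydroxy-1-(hydroxymethyl)ethoxy on an aromatic carbon. Thus 2-hydroxyethyl stands in place of 2-hydroxy-1-(hydroxymethyl)ethoxy. Going by the values given here, no measured step makes this exchange. Among the compounds with values here, only one measured step bears on it, and only indirectly: a number 1.40 log units lower from compound 1 to compound 2 (beyond the scatter). That large step, beyond the scatter, replaced methyl with 1-hydroxy-1-methylethyl on a saturated chain carbon bound to an oxygen on an aromatic ring.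

The 2-hydroxyethyl chain of compound 4 looks closer to the chain of compound 2 than to that of compound 3. Its number is therefore expected to fall between compound 3 at 1.3 and compound 2 at 3.6. A large step towards a higher number, beyond the scatter, is expected: a number 1.20 log units higher from compound 3 to compound 4 (beyond the scatter). For compound 4 the estimated value is 2.5, with an expected range from 1.9 to 3.2.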

Compound 4, distribution coefficient: 2.6
The estimate for compound 4 lay 0.10 log units below the measured number; low and high end bracket the measured number.
By their numbers in this assay, from the lowest: compound 3; then compound 4; then compound 2; then compound 1.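

In this assay, putting 2-hydroxyethyl in place of 2-hydroxy-1-(hydroxymethyl)ethoxy on the aromatic carbon of the shared core gives a number 1.30 log units higher from compound 3 to compound 4 (beyond the scatter), a large step. Among the compounds shown, this is the only step in which the oxygen on the aromatic ring leaves, whereas a number 1.40 log units lower from compound 1 to compound 2 (beyond the scatter), keeping that oxygen and changing only a group on the saturated chain carbon bound to it. The new step therefore shows that the number at this position also moves far beyond the scatter when the whole chain is exchanged, with the count falling from 2 hydrogen-bond donors to 1 and from 3 hydrogen-bond acceptors to 1, though nothing available explains its size.

The step removes the oxygen on the aromatic ring and a hydroxymethyl branch together, so the compounds shown cannot divide it between the two, and a 2-hydroxyethoxy chain on the same aromatic carbon would be needed to separate them. Going by these compounds, how an amine or a carboxylic acid at the end of a chain at this position would read in this assay also stays open.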